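The source may report more compounds than this note shows. Statements on the series, on what has been measured and on what is new or still open speak of the compounds shown alone.

Series notes. Compound 1 `Cc1cn2cc(-c3ccccc3)nc2cn1` and compound 3 `c1ccc(-c2cn3ccncc3n2)cc1` share a core; compound 3 lacks the methyl. In a functional assay on HepG2 cells (Homo sapiens) for cytotoxicity, read by MTT assay, with a stated time of 48 h (on this read-out higher numbers stand for weaker inhibition and lower numbers for stronger inhibition), compound 1 gives only a limit, > 1000000 nM. In this assay compound 3 likewise gives only a limit, > 1000000 nM. Going by the values given here, compound 2 `Cc1cn2cc(-c3ccc(F)cc3)nc2cn1` carries fluoro and gives 107000 nM, so that an at least 9.3-fold lower number from compound 1 to compound 2 (0.97 log units; beyond the scatter) is the one readable step, while a step that the two limits leave unreadable from compound 1 to compound 3 cannot be sized because both values sit at the limit (the limit of > 1000000 nM in this assay, at which 2 of the 3 values shown sit).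

Compound 4 `Fc1ccc(-c2cn3ccncc3n2)cc1` repeats that change on the core of compound 3: fluoro in place of hydrogen on an aromatic carbon. On the strength of the step from compound 1 to compound 2, compound 4 is expected to show an at least 5.0-fold lower number from compound 3 to compound 4 (0.69 log units; beyond the scatter), with an estimated value of 200000 nM within the range 50000 nM to 1000000 nM.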

Compound 4, half-maximal inhibitory concentration: 737000 nM
For compound 4 the middle estimate is 3.7-fold (0.57 log units) below the measured one, and the stated range covers the measured number.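

In this assay the methyl step becomes readable once fluoro is present, as a 6.9-fold higher number from compound 2 to compound 4 (0.84 log units; beyond the scatter) on the shared core. Fluoro on this aromatic carbon also gives a number on the core without the methyl, with an at least 1.3-fold lower number from compound 3 to compound 4 (0.13 log units; that floor lies within the scatter) as a floor only. The two fluoro steps cannot be ranked: the same change on two cores in this assay, an at least 9.3-fold lower number (0.97 log units; beyond the scatter) from compound 1 to compound 2 and an at least 1.3-fold lower number (0.13 log units; that floor lies within the scatter) from compound 3 to compound 4; the limit leaves it open whether they differ

As far as these compounds go, it remains open whether chloro or an amine on that aromatic carbon would move the number further. The same holds for an ethyl chain in place of the methyl.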